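A Chloro for Methoxy Swap at the Assay Limit

This account rests on a few compounds, and the source may have more. Where it says the series, first, only, none or still open, it means among the compounds named here.

Values so far in a functional assay on MDA-MB-231 cells (Homo sapiens) for antiproliferative activity, with a stated time of 48 h (on this read-out lower numbers stand for stronger inhibition and higher numbers for weaker inhibition), are these
- compound 1 `CCN(CC)c1ccc(-c2cccc(OC)c2)nn1` gives > 25000 nM
- compound 2 `CC(=O)c1ccc(-c2ccc(N3CCCC3)nn2)cc1` gives > 25000 nM
- compound 3 `COC(=O)c1cccc(-c2ccc(-n3cccc3)nn2)c1` gives > 25000 nM

None of these readings is a number, and each is a limit of the assay. For compound 1 the reading of > 25000 nM is such a limit. Compound 1 therefore stands with the other two at the limit of > 25000 nM in this assay, at which 3 of the 3 values shown sit, and cannot be ranked against them.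

Compound 4 `CCN(CC)c1ccc(-c2cccc(Cl)c2)nn1` keeps the core of compound 1 and differs from it by one change, chloro in place of methoxy on an aromatic carbon with the chloro meta to a large group. Within the data shown here, no two measured compounds differ in one place only, so the data hold no measured precedent for this swap. Since all three readings sit at the limit, they show no activity to build on, and none beyond the scatter is the size of change expected in this assay with no direction favoured. The expected step is a step that the limit leaves unreadable from compound 1 to compound 4 and this estimate is only tentative. Compound 4 is expected at 30000 nM within an estimated range of 12000 nM to 60000 nM in this assay, and most likely it will also be reported only as a limit.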

Compound 4, half-maximal inhibitory concentration: > 25000 nM
Compound 4 ended at the assay's limit; the forecaster's own chance of this, stated with the estimate: 75%; the middle value lies beyond the limit too.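

In this assay, among these compounds, compound 4 gives > 25000 nM, which is a limit of the assay, and the reading for compound 1 is a limit too, so no step between compound 1 and compound 4 can be read. All the readings stand together: the limit of > 25000 nM in this assay, at which 4 of the 4 values shown sit. The compounds shown leave open what chloro in place of methoxy does to a measurable potency in this assay.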